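Moving the Hydroxyl Around the Outer Ring

A few compounds are considered here, and "the series" means these few. Any claim that something is new, unique, unknown or untested is made for them only; others in the source may bear on it.

Compound 1 `CCCN(CCN1CCN(c2ccc(-c3ccc(OC)cc3)cc2)CC1)C1CCc2nc(N)sc2C1` is the reference point. Among the measured compounds shown here, in an assay on HEK293 cells for displacement of a labelled ligand from D(3) dopamine receptor (Rattus norvegicus) (on this read-out lower numbers stand for stronger inhibition and higher numbers for weaker inhibition), compound 1 gives 1.41 nM, the highest of the two numbers so far, although its only neighbour sits within the scatter. Compound 2 `CCCN(CCN1CCN(c2ccc(-c3cccc(O)c3)cc2)CC1)C1CCc2nc(N)sc2C1` gives 1.2 nM in this assay, and the step of a 1.2-fold lower number from compound 1 to compound 2 (0.07 log units; within the scatter) is too small to separate the two compounds. Compound 3 `CCCN(CCN1CCN(c2ccc(-c3ccccc3O)cc2)CC1)C1CCc2nc(N)sc2C1` has not been measured. It differs from compound 1 in one place: 2-hydroxyphenyl in place of 4-methoxyphenyl on an aromatic carbon. For the measured compounds named here, the only measured step that bears on this change is the one from compound 1 to compound 2, where a hydroxyphenyl likewise replaced the 4-methoxyphenyl and the number barely moved. Because that step a 1.2-fold lower number from compound 1 to compound 2 (0.07 log units; within the scatter) lay within the scatter, compound 3 is expected to stay close to compound 1, with an expected step of a 1.1-fold higher number from compound 1 to compound 3 (0.05 log units; within the scatter). The estimate for compound 3 is 1.6 nM, between 0.6 nM and 4.5 nM.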

Compound 3, inhibition constant: 1.8 nM
Compound 3: middle estimate off by 1.1-fold (0.05 log units), on the low side, and the stated range covers the measured number.
By their numbers in this assay, from the lowest: compounds 2, 1 and 3 (each within the scatter of the next).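

In this assay, the step of a 1.3-fold higher number from compound 1 to compound 3 (0.11 log units; within the scatter) lies within the scatter, and so does the step of a 1.5-fold higher number from compound 2 to compound 3 (0.18 log units; within the scatter). With 2-hydroxyphenyl, 3-hydroxyphenyl and 4-methoxyphenyl now all tried at this place, the read-out does not separate any of the three groups, so the 2-hydroxyphenyl of compound 3 adds a second hydroxyphenyl that is tolerated as well as the first. Nothing on hand explains why these groups read alike.

All three groups keep an oxygen on the outer ring, so the compounds shown leave open whether a plain phenyl, an amine or a carboxylic acid would read the same. A 4-hydroxyphenyl would also be informative, since it would change methoxy to hydroxyl while leaving the place of the oxygen as it is in compound 1.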